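The source may report more compounds than this note shows. Statements on the series, on what has been measured and on what is new or still open speak of the compounds shown alone.

Compound 3 `CCOC(=O)C1=C(C)NC(C)=C(C(=O)OCC)C1c1ccc(OCC(=O)NNC(=O)c2sccc2Cl)cc1` holds the highest of the three numbers in a functional assay on the whole organism (strain Wistar) for inhibition, with Rattus norvegicus as the target, read by paw edema, with stated times of 30 min and 2 h, at a dose of 20 mg/kg; on this read-out higher numbers stand for more inhibition at the one dose given (going by the name of the read-out) and lower numbers for less inhibition: compound 3 gives 57.2%, while compound 1 `CCOC(=O)C1=C(C)NC(C)=C(C(=O)OCC)C1c1ccc(OCC(=O)Nc2c(C)cccc2C)cc1` gives 47.8% and compound 2 `CCOC(=O)C1=C(C)NC(C)=C(C(=O)OCC)C1c1ccc(OCC(=O)NNC(=O)c2ccccc2)cc1` gives 44.5%. The gap a number 9.4 percentage points higher from compound 1 to compound 3 (within the scatter) stays within the scatter, whereas a number 12.7 percentage points higher from compound 2 to compound 3 (beyond the scatter) lies beyond it. Compound 4 `CCOC(=O)C1=C(C)NC(C)=C(C(=O)OCC)C1c1ccc(OCC(=O)NNC(=O)c2cccs2)cc1` differs from compound 3 by hydrogen in place of chloro on an aromatic carbon. Among the measured compounds shown here, no measured step removes the chloro on its own; the only step touching the thiophene, a number 12.7 percentage points higher from compound 2 to compound 3 (beyond the scatter), brought in the ring and the chloro together, so its size cannot be credited to the chloro. The expectation is therefore a small fall, a number 7.2 percentage points lower from compound 3 to compound 4 (within the scatter), not beyond the scatter. Compound 4 is estimated at 50%, between 40% and 62%.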

Compound 4, a percentage reported as inhibition, in the whole organism at one dose (the size of the read-out at that dose, not a potency): 62.2%
The estimate for compound 4 lay 12.2 percentage points below the measured number; measured number above the stated range.
By their numbers in this assay, from the lowest: compounds 2, 1, 3 and 4 (each within the scatter of the next, the first and the last beyond it).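

In this assay, hydrogen in place of chloro on this thiophene carbon stays within the scatter (a number 5 percentage points higher from compound 3 to compound 4 (within the scatter)), so the chloro is not needed for the higher number. The thiophen-2-yl group alone now accounts for a step beyond the scatter (a number 17.7 percentage points higher from compound 2 to compound 4 (beyond the scatter)), which the earlier step could not separate from the chloro. It also stands beyond the scatter against the 2,6-dimethylphenyl group (a number 14.4 percentage points higher from compound 1 to compound 4 (beyond the scatter)). No evidence on why these numbers arise is available here. Open, from the compounds shown here alone, is whether a methyl or methoxy group on this carbon, or a furan ring in place of thiophene, would read differently.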